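The compounds below may be only part of what the source reports. "The series", "measured", "known", "first", "only" and "open" are said of these compounds alone.

Compound 1 `O=C(Nc1cc(Sc2ncn[nH]2)c(O)c2ccccc12)c1ccc(Cl)cc1` gives 5520 nM. Compound 2 `O=C(Nc1cc(Sc2ncn[nH]2)c(O)c2ccccc12)c1cccc(Cl)c1` gives 85600 nM. Compound 3 `O=C(/C=C/c1ccc(Cl)cc1)Nc1cc(Sc2ncn[nH]2)c(O)c2ccccc12` gives only a limit of the assay, > 100000 nM.

These three values come from a functional assay on PC-3 cells (Homo sapiens) for antiproliferative activity, read by MTT assay, with a stated time of 48 h; a lower number here means a stronger inhibitor, a higher number a weaker inhibitor. Compound 1 holds the lowest number of the two full values, with a 16-fold higher number from compound 1 to compound 2 (1.19 log units; beyond the scatter) separating it from compound 2. Compound 3 sits at the limit of > 100000 nM in this assay, at which 1 of the 3 values shown sits, so the change from compound 1 reads an at least 18-fold higher number from compound 1 to compound 3 (1.25 log units; beyond the scatter). Both measured steps alter only the group on the carbonyl carbon.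

Compound 4 `O=C(Nc1cc(Sc2nncs2)c(O)c2ccccc12)c1ccc(Cl)cc1` differs from compound 1 elsewhere: 1,3,4-thiadiazol-2-yl in place of 1H-1,2,4-triazol-5-yl on a sulfur. For the measured compounds named here, no measured step touches that part of the shared core, so none of the measured steps bears directly on this change. The ring entering keeps the same size and the same count of hetero atoms, so the step expected in this assay for compound 4 is small, a 1.4-fold higher number from compound 1 to compound 4 (0.16 log units; within the scatter), and may lie within the scatter. Compound 4 is therefore estimated at 8000 nM, within a range from 2500 nM to 30000 nM.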

Compound 4, half-maximal inhibitory concentration: > 100000 nM
Compound 4: only a limit was reported; the forecaster's own chance of this, stated with the estimate: 5%; middle value at least 12-fold (1.09 log units) from the limit.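

In this assay, the change on the sulfur gives an at least 18-fold higher number from compound 1 to compound 4 (1.25 log units; beyond the scatter), so the result responds to this part of the molecule too, not only to the group on the carbonyl carbon. The leaving and entering rings have the same size and the same count of hetero atoms, so matching those features does not preserve the activity; the entering ring has a sulfur in place of a nitrogen and no hydrogen-bond donor. Compound 4 gives > 100000 nM, which is a limit and not a number, and it is the second such limit in this set: the limit of > 100000 nM in this assay, at which 2 of the 4 values shown sit.

For the compounds shown here, compound 3 and compound 4 both stand at limits, so no step between them can be read. As far as these compounds go, whether the ring sulfur or the missing donor matters stays open, as both change together here; a 1H-imidazol-2-yl ring or a methyl group on the sulfur would probe this position further.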